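Methylating One Hydroxy Group: From Compound 2 to Compound 4

This account rests on a few compounds, and the source may have more. Where it says the series, first, only, none or still open, it means among the compounds named here.

Of the compounds shown here, three built on a shared core have been tested in a functional assay on KB cells (Homo sapiens) for cytotoxicity; on this read-out lower numbers stand for an effect already at smaller amounts and higher numbers for an effect only at larger amounts of compound. Compound 1 `CCOc1cc(-c2ccccc2)nc2ccccc12` gives 6.7 ug/mL, and compound 3 `CC(C)Oc1cc(-c2ccccc2)nc2ccccc12` gives 4.2 ug/mL. Compound 2 `Oc1ccc2nc(-c3ccccc3)cc(O)c2c1` gives 0.41 ug/mL, the lowest of the three numbers and well beyond the scatter from both others.

Compound 4 `COc1ccc2nc(-c3ccccc3)cc(O)c2c1` differs from compound 2 in one place: methyl in place of hydrogen on an oxygen on an aromatic ring. For the measured compounds named here, the only recorded step, a 1.6-fold lower number from compound 1 to compound 3 (0.20 log units; within the scatter), adds a methyl at a different place, so it bears on this change only loosely; it does suggest that a single extra carbon need not move the number far. The expected step is therefore modest, a 2.0-fold higher number from compound 2 to compound 4 (0.29 log units; within the scatter). Compound 4 is estimated at 0.8 ug/mL, within 0.25 ug/mL to 2.5 ug/mL.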

Compound 4, half-maximal effective concentration: 0.08 ug/mL
The estimate for compound 4 lay 10-fold (1.00 log units) above the measured number, outside the stated range (below it).
By their numbers in this assay, from the lowest: compound 4; then compound 2; then compounds 3 and 1 (each within the scatter of the next).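

In this assay, replacing hydroxy with methoxy on this oxygen on an aromatic ring gives a 5.1-fold lower number from compound 2 to compound 4 (0.71 log units; beyond the scatter), so at this place a single added methyl moves the number beyond the scatter. The earlier methyl step, a 1.6-fold lower number from compound 1 to compound 3 (0.20 log units; within the scatter), sat at a different place and stayed within the scatter, so a methyl step need not be small. No measurement available here speaks to the reason for this change. Still open, from the compounds shown here alone, is how a longer chain such as butoxy on this oxygen would read. Going by these compounds, an amine in place of this oxygen is equally open.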